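Swapping an aryl ether for an aryl thioether on a shared core

The source may report more compounds than this note shows. Statements on the series, on what has been measured and on what is new or still open speak of the compounds shown alone.

Compound 1, `Nc1cc(N)c2nc(-c3ccccc3)c(Oc3ccc(Cl)c(Cl)c3)nc2c1`: 23400 nM
Compound 2, `Nc1cc(N)c2nc(-c3ccccc3)c(NCc3ccc(Cl)c(Cl)c3)nc2c1`: 4270 nM
Compound 3, `CCOC(=O)[C@H](CCC(=O)O)NC(=O)c1ccc(Sc2nc3cc(N)cc(N)c3nc2-c2ccccc2)cc1`: 63100 nM

These three compounds share one core and were tested in a functional assay on SK-MEL-2 cells (Homo sapiens) for inhibition, read by sulforhodamine B assay, with a stated time of 48 h; a lower number here means a stronger inhibitor of growth, a higher number a weaker inhibitor of growth. Compound 1 stands second highest of the three numbers. Compound 3 is nearest to it, with a number higher by a margin beyond the scatter, and compound 2 is furthest, with a number lower by a margin beyond the scatter. None of these pairs differs in just one place, so no single step can be read from them.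

Compound 4, `Nc1cc(N)c2nc(-c3ccccc3)c(Sc3ccc(F)cc3)nc2c1`, has not yet been measured in this assay. It differs from compound 1 as follows: (4-fluorophenyl)sulfanyl in place of 3,4-dichlorophenoxy on an aromatic carbon. The change sits on an aromatic carbon of the core, next to the ring nitrogen and ortho to a phenyl group.

Compound 3 also carries a sulfur link to an aromatic ring, yet its number is higher than that of compound 1; but compound 3 also bears a large extra chain, so its value gives little direct guidance. For compound 4 a small step is expected, a 1.5-fold lower number from compound 1 to compound 4 (0.17 log units; within the scatter), in the direction of a lower number but not clearly beyond the scatter. The estimate for compound 4 is 16000 nM, within a range from 4000 nM to 60000 nM.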

Compound 4, concentration for total growth inhibition: < 100000 nM
Compound 4: a limit, no number (the forecaster's own chance of this, stated with the estimate: 10%); the middle value lies beyond the limit too.
By their numbers in this assay, from the lowest: compound 2; then compound 1; then compound 3.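

Within the data shown here, the result for compound 4 is a limit of the assay and not a number, so no step from compound 1 to compound 4 can be read: the limit of < 100000 nM in this assay, at which 1 of the 4 values shown sits.

Going by these compounds, whether (4-fluorophenyl)sulfanyl in place of 3,4-dichlorophenoxy on the shared core gives a stronger or weaker inhibitor of growth stays open.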